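Swapping a Triazole for a Pyridine on a Cyanoguanidine Chain

The compounds below may be only part of what the source reports. "The series", "measured", "known", "first", "only" and "open" are said of these compounds alone.

Compound 1, `CN/C(=N/C#N)NCCCc1c[nH]c(C)n1`: < 5
Compound 2, `CN/C(=N/C#N)NCCCNc1nc(N)n[nH]1`: < 5
Compound 3, `N#C/N=C(/NCCCCNc1nc(N)n[nH]1)NCCSc1ccccc1`: < 5

All three measured compounds were tested in a functional assay on Sf9 cells for antagonist activity at histamine H2 receptor (Homo sapiens), read by scintillation counting and GTPgammaS binding, with a stated time of 90 min; a lower number here means a less potent compound, a higher number a more potent compound, by a factor of ten per unit of this negative logarithm. Each of the values listed for them is a limit of the assay rather than a number. Compound 1 gives < 5 in this assay, and that is a limit. Compound 2 gives < 5 in this assay, again a limit. Compound 3 likewise reaches only < 5 in this assay, a limit. So compound 3 stands where every other measured compound stands, at the limit of < 5 in this assay, at which 3 of the 3 values shown sit, and nothing among the measured compounds separates it from the rest.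

Compound 4, `N#C/N=C(/NCCCCNc1ccccn1)NCCSc1ccccc1`, has not yet been measured. It differs from compound 3 in one place: pyridin-2-yl in place of 3-amino-1H-1,2,4-triazol-5-yl on an amine nitrogen. Among the compounds with values here, no pair of measured compounds differs by a single change, so there is no measured step to lean on. Since compound 3 sits at the limit with < 5, the expected step of a number no lower from compound 3 to compound 4 (the limit leaves the size open) is small, with a fair chance that compound 4 also returns only a limit. Compound 4 is estimated at 5, with a range from 4.3 to 5.7.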

Compound 4, negative logarithm of the antagonist equilibrium constant: < 5
Compound 4 gave a limit, no number (the forecaster's own chance of this, stated with the estimate: 55%); the middle value sits exactly at the limit.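

No new step can be read from compound 3 to compound 4, because both compounds return only a limit, and the swap of groups therefore shows no readable effect: the limit of < 5 in this assay, at which 4 of the 4 values shown sit.

From the compounds shown here alone, what stays open is whether pyridin-2-yl and 3-amino-1H-1,2,4-triazol-5-yl on the amine nitrogen differ in potency at all, and how far any of these four compounds lies from that limit.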